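From ethyl to allyl: a small step

A few compounds are considered here, and "the series" means these few. Any claim that something is new, unique, unknown or untested is made for them only; others in the source may bear on it.

Measured so far in a functional assay on the whole organism with Rattus norvegicus as the target; a higher number here means that more compound is needed for the effect, a lower number that less compound is needed
Compound 1 `Nc1ccc2nc(N)sc2c1` gives > 10 mg/kg (a limit of the assay, not a number)
Compound 2 `Nc1nc2ccc(OCC(F)(F)F)cc2s1` gives 6.5 mg/kg
Compound 3 `CCn1c(=N)sc2cc(OC(F)(F)F)ccc21` gives 5 mg/kg

Compound 3 lies within the usual scatter of compound 2, so these two cannot be ranked. Next comes compound 4 `C=CCn1c(=N)sc2cc(OC(F)(F)F)ccc21` and its difference from compound 3 is vinyl in place of methyl on a saturated chain carbon bound to an aromatic nitrogen. Put simply, ethyl becomes allyl. Going by the values given here, no measured pair shows this change, so the expectation rests on compound 3 at 5 mg/kg and the small size of the change: no step in this assay beyond the scatter, in either direction. The estimated step of a 1.3-fold lower number from compound 3 to compound 4 (0.10 log units; within the scatter) is expected to stay within the scatter. For compound 4 the estimate is 4 mg/kg with an expected range from 1.5 mg/kg to 10 mg/kg in this measurement.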

Compound 4, dose for half-maximal effect: 7 mg/kg
Compound 4: middle estimate off by 1.8-fold (0.24 log units), on the low side, within the range that was stated.
By their numbers in this assay, from the lowest: compounds 3, 2 and 4 (each within the scatter of the next). At a limit, above all of these: compound 1.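

In this assay, going by these compounds alone, this pair gives the first readable step at this place, on a saturated chain carbon bound to an aromatic nitrogen, and it stays within the scatter: a 1.4-fold higher number from compound 3 to compound 4 (0.15 log units; within the scatter). Ethyl and allyl therefore cannot be told apart here, so the double bond of the allyl group brings no readable difference on this core. Nothing in the data at hand bears on this result.

Still open, from the compounds shown here alone, is whether a longer chain, such as butyl, or a chain ending in an amine or a carboxylic acid, would give a step beyond the scatter at this place. Also open, going by these compounds, is whether ethyl to allyl reads the same on a core carrying a group other than trifluoromethoxy.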